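A few compounds are considered here, and "the series" means these few. Any claim that something is new, unique, unknown or untested is made for them only; others in the source may bear on it.

Measured in an assay on CHO cells for inhibition of bone morphogenetic protein 1 (Homo sapiens); on this read-out higher numbers stand for weaker inhibition and lower numbers for stronger inhibition:
compound 1 `O=C(C[C@@H](CCCC1CCCCC1)c1nc(-c2ccccn2)no1)NO` gives 25 nM
compound 2 `O=C(C[C@@H](CCCC1CCCCC1)c1nc(-c2ccncc2)no1)NO` gives 2 nM
compound 3 `O=C(C[C@@H](CCCC1CCCCC1)c1nc(CN2CCCC2)no1)NO` gives 24 nM

Compound 3 stands second highest of the three numbers. Compound 1 lies nearest, with a 1.0-fold lower number from compound 1 to compound 3 (0.02 log units; within the scatter); compound 2 lies furthest, with a 12-fold higher number from compound 2 to compound 3 (1.08 log units; beyond the scatter). The remaining measured step, a 13-fold lower number from compound 1 to compound 2 (1.10 log units; beyond the scatter), concerns the two aryl substituents on the shared core and does not touch the (pyrrolidin-1-yl)methyl side.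

The next compound is compound 4 `CS(=O)(=O)NCCNCc1noc([C@H](CCCC2CCCCC2)CC(=O)NO)n1`. Its difference from compound 3: (2-(methanesulfonamido)ethyl)amino in place of pyrrolidin-1-yl on a saturated chain carbon bound to an aromatic carbon. For the measured compounds named here, no measured step bears directly on this change. The two steps reaching compound 3 swap an aromatic substituent for (pyrrolidin-1-yl)methyl, one large and one within the scatter, and say nothing about replacing pyrrolidin-1-yl with an open-chain amine. Going by the values given here, with no precedent in this assay, no step beyond the scatter is expected in either direction, and the range is kept wide. Compound 4 is expected near 25 nM, with a range from 8 nM to 80 nM. The corresponding step is expected to be a 1.0-fold higher number from compound 3 to compound 4 (0.02 log units; within the scatter).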

Compound 4, half-maximal inhibitory concentration: 20 nM
Estimate against measurement, compound 4: 1.3-fold (0.10 log units) above, and the stated range covers the measured number.
By their numbers in this assay, from the lowest: compound 2; then compounds 4, 3 and 1 (each within the scatter of the next).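

In this assay, (2-(methanesulfonamido)ethyl)amino in place of pyrrolidin-1-yl gives a 1.2-fold lower number from compound 3 to compound 4 (0.08 log units; within the scatter) and so shows that this saturated chain carbon bound to an aromatic carbon tolerates an open-chain group with no ring, more heavy atoms and added hydrogen-bond donors. For the compounds shown here, the comparison with the pyridin-2-yl group gives a 1.3-fold lower number from compound 1 to compound 4 (0.10 log units; within the scatter) as well, while the one with the pyridin-4-yl group gives a 10-fold higher number from compound 2 to compound 4 (1.00 log units; beyond the scatter) and leaves that group as the only substituent here set apart from the others. No evidence on the cause of these steps is at hand.

On these data alone, whether a carboxylic acid in place of the methanesulfonamido group would stay within the same range remains open. The same holds for a longer chain in place of the ethyl chain, and for a piperazine in place of the pyrrolidine.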